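This account rests on a few compounds, and the source may have more. Where it says the series, first, only, none or still open, it means among the compounds named here.

Measured so far in a functional assay on BJAB cells (Homo sapiens) for antiproliferative activity, with a stated time of 4 days; on this read-out lower numbers stand for an effect already at smaller amounts and higher numbers for an effect only at larger amounts of compound:
- compound 1 `Cc1nn(-c2nc(-c3ccc(Cl)c(Cl)c3)c(SC(C)C)s2)c(C(=O)O)c1-c1cnccn1`: 14000 nM
- compound 2 `Cc1nn(-c2nc(-c3ccc(Cl)c(Cl)c3)c(SC(C)C)s2)c(C(=O)O)c1-c1cnn(C)c1`: 6800 nM
- compound 3 `Cc1nn(-c2nc(-c3ccc(Cl)c(Cl)c3)c(SC(C)C)s2)c(C(=O)O)c1-c1cccc(F)c1`: 900 nM

Compound 3 holds the lowest number of the three, with a 16-fold lower number from compound 1 to compound 3 (1.19 log units; beyond the scatter) and a 7.6-fold lower number from compound 2 to compound 3 (0.88 log units; beyond the scatter) both beyond the scatter. The smaller change between the two heteroaryl compounds is a 2.1-fold lower number from compound 1 to compound 2 (0.31 log units; beyond the scatter).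

Compound 4 `Cc1nn(-c2nc(-c3ccc(Cl)c(Cl)c3)c(SC(C)C)s2)c(C(=O)O)c1-c1ccccc1Cl` differs from compound 3 by 2-chlorophenyl in place of 3-fluorophenyl on an aromatic carbon. Among the measured compounds shown here, no measured step exchanges one halogenated phenyl for another; the steps seen so far all involve a heteroaryl ring, so they give only a loose anchor. The expectation is that compound 4 stays close to compound 3, with no step beyond the scatter clearly indicated: a 1.2-fold higher number from compound 3 to compound 4 (0.09 log units; within the scatter) is the estimated step. Compound 4 is thus estimated at 1100 nM, in a range of 400 nM to 3000 nM.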

Compound 4, half-maximal effective concentration: 13100 nM
Beside the measured number, compound 4's estimate is 12-fold (1.08 log units) below it; measured number above the stated range.
By their numbers in this assay, from the lowest: compound 3; then compounds 2, 4 and 1 (each within the scatter of the next, the first and the last beyond it).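

In this assay a halogenated phenyl at this position does not by itself hold the low number: a 15-fold higher number from compound 3 to compound 4 (1.16 log units; beyond the scatter) comes with 2-chlorophenyl in place of 3-fluorophenyl, two groups with the same heavy-atom count. Compound 4 stands level with both heteroaryl compounds, with a 1.9-fold higher number from compound 2 to compound 4 (0.28 log units; within the scatter) and a 1.1-fold lower number from compound 1 to compound 4 (0.03 log units; within the scatter) both within the scatter, so a carbon-only ring alone does not set the number. Nothing measured here bears on what lies behind this step.

Open, from the compounds shown here alone, is whether the halogen or its place on the phenyl ring carries the step. A 3-chlorophenyl or 2-fluorophenyl group at this position would separate the two.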